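The source may report more compounds than this note shows. Statements on the series, on what has been measured and on what is new or still open speak of the compounds shown alone.

In an assay on HEK293 cells for positive allosteric modulation of metabotropic glutamate receptor 3 (Rattus norvegicus), read by thallium flux, with a stated time of 2.5 min (on this read-out lower numbers stand for smaller maximal responses and higher numbers for larger maximal responses), the measured compounds stand as follows:

compound 1, `COc1cc(C(=O)O)ccc1OCCCCOc1ccc(C(=O)CC(C)(C)C)c(O)c1C`, gives 109%
compound 2, `COc1cc(C(=O)O)ccc1OCCCCOc1ccc(C(=O)CC(C)C)c(O)c1C`, gives 73.9%
compound 3, `Cc1c(OCCCCOc2cccc(C(=O)O)c2)ccc(C(=O)CC(C)C)c1C`, gives 18.3%

Compound 2 holds the second highest of the three numbers: compound 1 sits above it and compound 3 below it, both gaps beyond the scatter. Going by the values given here, the one counted step in the set, a number 35.1 percentage points lower from compound 1 to compound 2 (beyond the scatter), concerns the saturated chain and not the aromatic ring, so it does not bear directly on the change at hand.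

Compound 4, `Cc1c(OCCCCOc2ccc(C(=O)O)cc2)ccc(C(=O)CC(C)C)c1O`, differs from compound 2 in one place:
hydrogen in place of methoxy on an aromatic carbon

Among the compounds with values here, no measured pair isolates this change. Compound 3 also lacks the methoxy, yet it differs from compound 2 in more than one place, so its low value can only hint at the direction. Taking that hint with caution, a downward step from compound 2 is expected in this assay, though its size is uncertain and it may well fall within the scatter.

The expected step is a number 18.9 percentage points lower from compound 2 to compound 4 (beyond the scatter). Compound 4 is estimated at 55%, with a range from 25% to 90%.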

Compound 4, largest response reached (reported as percent of maximum), in percent of the reference or control that the assay uses: 51.9%
Compound 4: the middle estimate sits 3.1 percentage points above what was measured; low and high end bracket the measured number.
By their numbers in this assay, from the lowest: compound 3; then compound 4; then compound 2; then compound 1.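

In this assay the swap of methoxy for hydrogen on this aromatic carbon, ortho to a large group and meta to a carboxy group, now has a reading of its own, with a number 22 percentage points lower from compound 2 to compound 4 (beyond the scatter) as a modest step, where compound 3 could only hint at a direction. The methoxy thus counts toward the maximal response within this pair, yet a clear response survives without it, as compound 4 still gives 51.9% in this series. No measurement on these compounds accounts for the step, so the reading describes the change and gives no cause.

Going by these compounds, whether the step is particular to methoxy stays open: an ethoxy group, a fluorine or a chlorine on the same aromatic carbon would show whether other substituents there match compound 2 or whether only methoxy does. Also open, on these data alone, is how this replacement behaves with the chain of compound 1, since a number 35.1 percentage points lower from compound 1 to compound 2 (beyond the scatter) marks the saturated chain as a second place that moves this read-out, and the two changes may or may not add up.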